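This account rests on a few compounds, and the source may have more. Where it says the series, first, only, none or still open, it means among the compounds named here.

Measured so far:
- compound 1 `OC1CN(CCCCc2ccccc2)CCc2cc(OCc3ccccc3)ccc21`: 293 nM
- compound 2 `COc1ccc(C2(CCCN3CCc4cc(OCc5ccccc5)ccc4C(O)C3)OCC(C)(C)CO2)cc1`: > 1000 nM
- compound 3 `CN(Cc1ccccc1)C(=O)CN1CCc2cc(OCc3ccccc3)ccc2C(O)C1`: > 1000 nM

For the measured compounds named here, in an assay for displacement of a labelled ligand from Sigma non-opioid intracellular receptor 1 (Cavia porcellus), read by scintillation counting, with a stated time of 180 min (on this read-out lower numbers stand for stronger inhibition and higher numbers for weaker inhibition), compound 1 gives 293 nM, the only numerical value shown in the set. Compound 2 is reported in this assay only as a limit, > 1000 nM. Compound 3 is likewise reported only as a limit, > 1000 nM. Two of three results thus sit at the limit of > 1000 nM in this assay, at which 2 of the 3 values shown sit, and compound 1 alone carries a number.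

Compound 4 `OC1CN(C2CCC3(CC2)OCCO3)CCc2cc(OCc3ccccc3)ccc21` is not yet measured. It differs from compound 1 by a group of 10 heavy atoms (8 carbon, 2 oxygen; one five-membered non-aromatic ring with 2 hetero atoms, one six-membered non-aromatic ring of carbon only) in place of a group of 10 heavy atoms (10 carbon; one six-membered aromatic ring of carbon only), on an amine nitrogen in a ring. Going by the values given here, no measured pair shows a change at that nitrogen, so the size of the step rests on the exchange itself; the aromatic ring of the 4-phenylbutyl is lost and nothing in the set shows a saturated ketal-bearing substituent holding potency. The expectation is a step toward weaker inhibition, beyond the scatter, a 5.1-fold higher number from compound 1 to compound 4 (0.71 log units; beyond the scatter). Compound 4 is estimated at 1500 nM, with a range from 300 nM to 8000 nM, and a fair chance that this assay returns only a limit.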

Compound 4, inhibition constant: 183 nM
The estimate for compound 4 lay 8.2-fold (0.91 log units) above the measured number; the measured number lies below the stated range.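

In this assay, replacing the 4-phenylbutyl on the amine nitrogen in a ring with the group bearing a five-membered non-aromatic ring with 2 hetero atoms and a six-membered non-aromatic ring of carbon only gives a 1.6-fold lower number from compound 1 to compound 4 (0.20 log units; within the scatter). The pair therefore cannot be told apart, and at this nitrogen a numerical value does not depend on keeping the six-membered aromatic ring of the 4-phenylbutyl. The substituent still matters, since compound 2 and compound 3 are reported only as limits, not as numbers: the limit of > 1000 nM in this assay, at which 2 of the 4 values shown sit.

The compounds shown leave open whether the two ketal oxygens contribute, which a plain cyclohexyl or a cyclohexanone at this nitrogen would test. They also leave open whether the hydroxy group is needed, which the same core carrying a ketone there would test.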